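Solubility notes on a fused diaminonitrile series

This account rests on a few compounds, and the source may have more. Where it says the series, first, only, none or still open, it means among the compounds named here.

Measured compounds:
- compound 1, `N#Cc1c(N)nc2nc(C3CCCCC3)ncc2c1N`: 81000 nM
- compound 2, `CC(C)(C)c1nc(CCCCC#N)c2c(N)c(C#N)c(N)nc2n1`: 16000 nM

In a physicochemical assay for solubility, in phosphate buffer, with a stated time of 18 h (a higher number here means a more soluble compound, a lower number a less soluble compound), compound 1 gives 81000 nM, while compound 2 gives 16000 nM. Compound 2 therefore stands at the lower of the two numbers, and the gap to compound 1 lies beyond the scatter. Among the compounds with values here, the two compounds differ in more than one place, so no single step between them can be read off.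

Compound 3, `CC(C)(C)c1nc(-c2ccn[nH]2)c2c(N)c(C#N)c(N)nc2n1`, has not yet been measured. It differs from compound 2 in one place: 1H-pyrazol-5-yl in place of 4-cyanobutyl on an aromatic carbon.

Within the data shown here, no measured step guides this change. On the numbers at hand, the expectation for compound 3 is a modest rise, with a 1.6-fold higher number from compound 2 to compound 3 (0.19 log units; within the scatter) the estimated step, though it may fall within the scatter. In this assay compound 3 is thus expected to give 25000 nM, in a range from 6000 nM to 100000 nM.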

Compound 3, solubility: 13500 nM
Compound 3: the middle estimate sits 1.9-fold (0.27 log units) above what was measured, and the stated range covers the measured number.
By their numbers in this assay, from the lowest: compounds 3 and 2 (each within the scatter of the next); then compound 1.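

In this assay, the series now has its first single-place step, on the aromatic carbon opposite the ring nitrogen: 1H-pyrazol-5-yl in place of 4-cyanobutyl gives a 1.2-fold lower number from compound 2 to compound 3 (0.07 log units; within the scatter) and stays within the scatter. The two groups differ plainly in kind, an open chain ending in a nitrile against a five-membered aromatic ring with a hydrogen-bond donor, yet this one exchange at this position separates compound 2 and compound 3 by no more than repeated measurements would. Nothing measured here accounts for this result.

Steps to compound 1 cannot be read, as it differs from both other compounds in more than one place. On these data alone, whether a primary amine, a carboxylic acid or a longer chain on this aromatic carbon would also stay within the scatter remains open.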